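The compounds below may be only part of what the source reports. "The series", "measured", "known", "first", "only" and "open" are said of these compounds alone.

Measured compounds in an assay on isolated protein for displacement of a labelled ligand from metabotropic glutamate receptor 5 (Homo sapiens), with a stated time of 60 min, tested at 1 uM; on this read-out higher numbers stand for more inhibition at the one concentration tested (going by the name of the read-out) and lower numbers for less inhibition:

compound 1 `CC1CCN(c2c(S(=O)(=O)c3cccc(F)c3)cnc3ccc(F)cc23)CC1`: 76%
compound 2 `CC1CCN(c2c(S(=O)(=O)c3cccc(F)c3)cnc3ccc(Cl)cc23)CC1`: 58%
compound 3 `COc1ccc2ncc(S(=O)(=O)c3cccc(F)c3)c(N3CCC(C)CC3)c2c1`: 68%

Among the measured compounds shown here, compound 2 carries the smallest number of the three, but the step of a number 10 percentage points higher from compound 2 to compound 3 (within the scatter) is within the scatter, so compound 2 and compound 3 cannot be told apart on these numbers; only the step of a number 18 percentage points lower from compound 1 to compound 2 (beyond the scatter) is beyond the scatter, and it is the one clear separation in the set. All three measured steps change the substituent on the shared core, not the sulfonyl-bearing phenyl ring.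

Compound 4 `CC1CCN(c2c(S(=O)(=O)c3cc(F)cc(F)c3)cnc3ccc(Cl)cc23)CC1` differs from compound 2 by fluoro in place of hydrogen on an aromatic carbon. For the measured compounds named here, no measured step touches this ring, so there is no direct precedent; the change is small in size, and in the absence of any bearing step the expectation is no step beyond the scatter in this assay. Compound 4 is therefore estimated at 58%, with a range of 40% to 75%, an expected step of no change at the digits printed from compound 2 to compound 4 (within the scatter).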

Compound 4, a percentage reported as inhibition, at one concentration (the size of the read-out at that concentration, not a potency): 93%
Compound 4: the middle estimate sits 35 percentage points below what was measured; measured number above the stated range.
By their numbers in this assay, from the lowest: compounds 2, 3 and 1 (each within the scatter of the next, the first and the last beyond it); then compound 4.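

On the sulfonyl-bearing phenyl ring, going from 3-fluorophenyl to 3,5-difluorophenyl in this assay gives a number 35 percentage points higher from compound 2 to compound 4 (beyond the scatter) and this is larger than any printed step among compound 1, compound 2 and compound 3, all of which change the substituent on the shared core. This ring, untouched by those earlier steps, is therefore a place where the read-out responds strongly to a change of just 1 heavy atom. Nothing at hand bears on what lies behind this step.

As far as these compounds go, whether the same change carries over to the fluoro-bearing core of compound 1 or the methoxy-bearing core of compound 3 stays open. Also open, from the compounds shown here alone, is how this ring responds to a nitrile or an amine in place of the added fluoro.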